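A few compounds are considered here, and "the series" means these few. Any claim that something is new, unique, unknown or untested is made for them only; others in the source may bear on it.

Measured so far:
compound 1 `CCCc1ccc(/C=C/C(=O)Nc2ccc3nc(CCC)cc(N)c3c2)cc1` — 4 nM
compound 2 `CC(C)(C)c1cc(N)c2cc(NC(=O)/C=C/c3ccc(C(F)(F)F)cc3)ccc2n1` — 0.3 nM
compound 3 `CCCc1cc(N)c2cc(NC(=O)/C=C/c3ccc(C(C)(C)C)cc3)ccc2n1` — 22 nM

In an assay on isolated protein for displacement of a labelled ligand from melanin-concentrating hormone receptor 1 (Homo sapiens) (a lower number here means a stronger inhibitor, a higher number a weaker inhibitor), compound 3 gives 22 nM, the highest of the three numbers. Its nearest neighbour is reached through a 5.5-fold higher number from compound 1 to compound 3 (0.74 log units; beyond the scatter), the change being tert-butyl in place of propyl on an aromatic carbon, a shift beyond the scatter. Compound 2 gives 0.3 nM but differs from compound 3 in two places, so the gap between those two values is read only as the values show.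

Compound 4 `CCCc1cc(N)c2cc(NC(=O)/C=C/c3ccc(N)cc3)ccc2n1` differs from compound 3 by amino in place of tert-butyl on an aromatic carbon. Going by the values given here, the single measured step at this position, a 5.5-fold higher number from compound 1 to compound 3 (0.74 log units; beyond the scatter), shows that swapping groups here moves the number modestly; no measured compound carries an amino group at this place, so the direction is open. A step of about a 1.1-fold lower number from compound 3 to compound 4 (0.04 log units; within the scatter) in this assay is therefore expected, staying near the scatter. Compound 4 is estimated at 20 nM, with a range from 4 nM to 100 nM.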

Compound 4, half-maximal inhibitory concentration: 190 nM
Compound 4: the middle estimate sits 9.5-fold (0.98 log units) below what was measured; the whole stated range lies below it.
By their numbers in this assay, from the lowest: compound 2; then compound 1; then compound 3; then compound 4.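

In this assay, amino, with its single heavy atom and one hydrogen-bond donor, gives a higher number than either carbon chain at this position (an 8.6-fold higher number from compound 3 to compound 4 (0.94 log units; beyond the scatter); a 48-fold higher number from compound 1 to compound 4 (1.68 log units; beyond the scatter)). The earlier step compared only propyl and tert-butyl, whereas these two steps show that a group carrying nitrogen can move the number further than the change between those two chains, with propyl giving the lowest number of the three groups on the shared core. Nothing available here bears on the reason for this.

As far as these compounds go, whether other nitrogen groups, such as a dimethylamino or an acetamido group, follow amino remains open, as does the behaviour of a methoxy group or a chlorine atom at this position. Trifluoromethyl occurs only in compound 2, which also differs elsewhere, so its contribution at this position cannot be separated.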